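A few compounds are considered here, and "the series" means these few. Any claim that something is new, unique, unknown or untested is made for them only; others in the source may bear on it.

Compound 2 `COc1cc(-c2nn(-c3cccc(NC(=O)Nc4cccc(C(F)(F)F)c4)c3)cc2-c2ccncc2)ccc1Cl` gives 3430 nM in a functional assay on COLO 205 cells (Homo sapiens) for inhibition, read by sulforhodamine B assay, with a stated time of 48 h; on this read-out higher numbers stand for lower toxicity in this test and lower numbers for higher toxicity in this test. Among the two numbers shown it stands alongside compound 1 `COc1cc(-c2nn(-c3cccc(NC(=O)Nc4ccc(Cl)c(Cl)c4)c3)cc2-c2ccncc2)ccc1Cl`, which gives 3140 nM in this assay; the gap is a 1.1-fold higher number from compound 1 to compound 2 (0.04 log units; within the scatter), so the two are indistinguishable here. Compound 3 `COc1cc(-c2nn(-c3cccc(NC(=O)c4ccc(Cl)c(C(F)(F)F)c4)c3)cc2-c2ccncc2)ccc1Cl` differs from compound 2 by 4-chloro-3-(trifluoromethyl)phenyl in place of (3-(trifluoromethyl)phenyl)amino on a carbonyl carbon. Among the measured compounds shown here, the single measured step, from compound 1 to compound 2, only exchanged substituents on the group attached to the amide-type nitrogen and changed nothing beyond the scatter; no measured step touches the carbonyl carbon itself. The expected step of a 1.0-fold higher number from compound 2 to compound 3 (0.01 log units; within the scatter) is therefore taken as small, and compound 3 is estimated at 3500 nM, within 1200 nM to 10000 nM.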

Compound 3, concentration lethal to 50% of the cells: > 32500 nM
Compound 3 ended at the assay's limit (the forecaster's own chance of this, stated with the estimate: 5%); middle value at least 9.2-fold (0.96 log units) from the limit.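

Earlier changes to the outer ring left the number within the scatter, but the link at the carbonyl carbon matters. In this assay, 4-chloro-3-(trifluoromethyl)phenyl in place of the amino-linked groups gives an at least 9.4-fold higher number from compound 2 to compound 3 (0.97 log units; beyond the scatter) and an at least 10-fold higher number from compound 1 to compound 3 (1.01 log units; beyond the scatter), so toxicity in this test falls. The value of compound 3 is a limit, not a number: the limit of > 32500 nM in this assay, at which 1 of the 3 values shown sits.

This change removes the amino nitrogen and adds a chlorine together, so the compounds shown do not separate the two. A plain 3-(trifluoromethyl)phenyl group on the carbonyl carbon would remove only the nitrogen.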